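From Isopropyl to Benzyl on the Double-Bonded Nitrogen

A few compounds are considered here, and "the series" means these few. Any claim that something is new, unique, unknown or untested is made for them only; others in the source may bear on it.

Of the compounds shown here, three sharing one core have been tested in an assay on DDT1 cells (Cricetulus griseus) for binding affinity to adenosine receptor A1 (Homo sapiens), read by radioligand binding; on this read-out higher numbers stand for weaker inhibition and lower numbers for stronger inhibition. Compound 1 `C/N=C(\S)OC[C@H]1OC(n2cnc3c(NC4CCOC4)nc(Cl)nc32)[C@H](O)[C@@H]1O` gives 71 nM, compound 2 `CC/N=C(\S)OC[C@H]1OC(n2cnc3c(NC4CCOC4)nc(Cl)nc32)[C@H](O)[C@@H]1O` gives 55 nM, and compound 3 `CC(C)/N=C(\S)OC[C@H]1OC(n2cnc3c(NC4CCOC4)ncnc32)[C@H](O)[C@@H]1O` gives 36 nM. Compound 3 has the lowest of the three numbers, but its gaps to compound 2 and to compound 1 both sit within the scatter, so none of the three can be called stronger than another.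

Compound 4 `O[C@@H]1[C@@H](CO/C(S)=N/Cc2ccccc2)OC(n2cnc3c(NC4CCOC4)ncnc32)[C@@H]1O` is compound 3 with benzyl in place of isopropyl on a double-bonded nitrogen. Within the data shown here, the only measured single change, a 1.3-fold lower number from compound 1 to compound 2 (0.11 log units; within the scatter), also enlarged the group on this double-bonded nitrogen and barely moved the number. Benzyl is a larger enlargement, and no measured pair mirrors it, so no step beyond the scatter is expected. The expected step is a 1.0-fold lower number from compound 3 to compound 4 (0.01 log units; within the scatter). Compound 4 is estimated at 35 nM, ranging from 12 nM to 110 nM.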

Compound 4, inhibition constant: 12 nM
Compound 4: the middle estimate sits 2.9-fold (0.46 log units) above what was measured; measured number inside the range.
By their numbers in this assay, from the lowest: compound 4; then compounds 3, 2 and 1 (each within the scatter of the next).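

Benzyl in place of isopropyl on the double-bonded nitrogen gives the first step at this position that lies beyond the scatter in this assay (a 3.0-fold lower number from compound 3 to compound 4 (0.48 log units; beyond the scatter)). Among these compounds, the only earlier step here stayed within the scatter (a 1.3-fold lower number from compound 1 to compound 2 (0.11 log units; within the scatter)), so this result shows that the group on this nitrogen can shift the number. Nothing measured here explains the shift.

The compounds shown leave open whether the aromatic ring or simply the added carbons matter more. A longer chain such as hexyl, or a cyclohexylmethyl group, at this position would help separate the two.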